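A few compounds are considered here, and "the series" means these few. Any claim that something is new, unique, unknown or untested is made for them only; others in the source may bear on it.

Working notes on the series. In a functional assay on KB cells (Homo sapiens) for antiproliferative activity, read by colorimetric assay and MTT assay (on this read-out lower numbers stand for stronger inhibition and higher numbers for weaker inhibition), compound 2 `O=[N+]([O-])c1ccc(S(=O)(=O)Nc2cccc3cc(Cl)[nH]c23)cc1` gives 18 ug/mL and compound 1 `O=[N+]([O-])c1ccc(S(=O)(=O)Nc2cccc3cc[nH]c23)cc1` gives 15 ug/mL. These two numbers lie within the scatter of each other, as the step of a 1.2-fold higher number from compound 1 to compound 2 (0.08 log units; within the scatter) shows. Compound 3 `O=[N+]([O-])c1ccc(S(=O)(=O)Nc2cccc3cc(O)[nH]c23)cc1` is reported only as a limit, > 100 ug/mL.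

The next change leads to compound 4 `Cc1ccc(S(=O)(=O)Nc2cccc3cc(Cl)[nH]c23)cc1`, with methyl in place of nitro on an aromatic carbon. Within the data shown here, no measured step touches this nitro group, so the evidence is indirect. The chloro change, a 1.2-fold higher number from compound 1 to compound 2 (0.08 log units; within the scatter), stays within the scatter. The two hydroxy steps, an at least 6.6-fold higher number from compound 1 to compound 3 (0.82 log units; beyond the scatter) and an at least 5.5-fold higher number from compound 2 to compound 3 (0.74 log units; beyond the scatter), go beyond it, which shows that this assay can respond strongly to a single substitution on the core. Those steps occur elsewhere on the molecule, however, and they give no direction for the present change.

The working expectation is therefore no step beyond the scatter, with either direction open and a wide margin for a larger move. The estimated step is a 1.1-fold higher number from compound 2 to compound 4 (0.05 log units; within the scatter). For compound 4 the expected value is 20 ug/mL, with an estimated range from 5 ug/mL to 70 ug/mL.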

Compound 4, half-maximal inhibitory concentration: 0.11 ug/mL
The estimate for compound 4 lay 180-fold (2.26 log units) above the measured number, outside the stated range (below it).
By their numbers in this assay, from the lowest: compound 4; then compounds 1 and 2 (each within the scatter of the next). At a limit, above all of these: compound 3.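

In this assay, among these compounds, the step of a 160-fold lower number from compound 2 to compound 4 (2.21 log units; beyond the scatter) shows that the aromatic carbon para to a large group, a place no earlier compound varied, is one where a single exchange moves the number strongly. The earlier compounds shown here differ from each other at another place on the molecule and give no reading on this one; here both compounds carry measured numbers, and the direction with methyl in place of nitro is toward stronger inhibition. No measured property at hand bears on the size of this step.

With only nitro and methyl shown at this carbon, it stays open whether the shift belongs to the arrival of methyl or to the departure of nitro, and an amine, a methoxy group or a carboxylic acid at the same place would help to separate these two readings. On these data alone, compound 4 also carries chloro, so it remains open whether methyl in place of nitro gives a step of similar size on the core of compound 1, which has hydrogen at that carbon instead.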